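The source may hold more compounds than are shown below. What is called first, only, known or untested is meant among the compounds shown, and "the series" means these compounds.

Compound 1 `Cc1noc(C)c1-c1cnc(N)c(Oc2ccc(C(=O)NC3CCCC3)cc2)n1`: 12800 nM
Compound 2 `Cc1noc(C)c1-c1cnc(N)c(Oc2ccc(C(=O)Nc3ccccc3Cl)cc2)n1`: > 100000 nM (a limit of the assay, not a number)
Compound 3 `Cc1noc(C)c1-c1cnc(N)c(Oc2ccc(C(=O)Nc3cccc(Cl)n3)cc2)n1`: 35700 nM

All three compounds were tested in a functional assay on HepG2 cells (Homo sapiens) for inhibition, read by MTT assay, with a stated time of 72 h; on this read-out higher numbers stand for weaker inhibition and lower numbers for stronger inhibition. Of the two true numbers, compound 3 holds the higher: a 2.8-fold higher number from compound 1 to compound 3 (0.45 log units; beyond the scatter). Compound 4 `Cc1noc(C)c1-c1cnc(N)c(Oc2ccc(C(=O)Nc3ncccc3Cl)cc2)n1` keeps the same atoms but joins them differently, with 3-chloropyridin-2-yl in place of 6-chloropyridin-2-yl on an amide-type nitrogen. The closest measured guide is the swap between the two chlorinated aromatic groups: an at least 2.8-fold lower number from compound 2 to compound 3 (0.44 log units; beyond the scatter). Compound 4 carries a chlorine numbered differently from that of compound 3, and its group may behave more like the 2-chlorophenyl of compound 2. A modest rise is therefore expected in this assay, an estimated 1.5-fold higher number from compound 3 to compound 4 (0.19 log units; within the scatter). For compound 4 the expected value is 55000 nM, with an estimated range of 22000 nM to 100000 nM.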

Compound 4, half-maximal inhibitory concentration: 27200 nM
Beside the measured number, compound 4's estimate is 2.0-fold (0.31 log units) above it; the range from low to high includes it.
By their numbers in this assay, from the lowest: compound 1; then compounds 4 and 3 (each within the scatter of the next). At a limit, above all of these: compound 2.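

Moving the chlorine, from 6-chloropyridin-2-yl to 3-chloropyridin-2-yl, makes no change that can be told from scatter (a 1.3-fold lower number from compound 3 to compound 4 (0.12 log units; within the scatter)). Compound 4 still reads clearly better than the 2-chlorophenyl amide (an at least 3.6-fold lower number from compound 2 to compound 4 (0.56 log units; beyond the scatter)), yet it does not match the cyclopentyl amide (a 2.1-fold higher number from compound 1 to compound 4 (0.33 log units; beyond the scatter)). Compound 2 stands at a limit, not a number: the limit of > 100000 nM in this assay, at which 1 of the 4 values shown sits.

Open, on these data alone, is whether a methoxy group or an amine in place of the chlorine would change the number. Also open, as far as these compounds go, is whether a cyclohexyl group or a longer chain on the amide-type nitrogen would give a lower number than compound 1.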